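The source may report more compounds than this note shows. Statements on the series, on what has been measured and on what is new or still open speak of the compounds shown alone.

Among the measured compounds shown here, in a functional assay on A549 cells (Homo sapiens) for cytotoxicity, read by MTT assay, with a stated time of 72 h (a lower number here means a stronger inhibitor, a higher number a weaker inhibitor), compound 1 `O=C(Nc1ccc(-n2ncc3c(Cl)cccc32)cc1)Nc1ccc(Cl)c(C(F)(F)F)c1` gives 3100 nM, the lower of the two numbers measured so far. Compound 2 `COc1cccc2c1cnn2-c1ccc(NC(=O)Nc2ccc(Cl)c(C(F)(F)F)c2)cc1` gives 3700 nM in this assay, and the change from compound 1 to compound 2 gave a 1.2-fold higher number from compound 1 to compound 2 (0.08 log units; within the scatter), a difference too small to read as a real change. Compound 3 `O=C(Nc1ccc(-n2ncc3cnccc32)cc1)Nc1ccc(Cl)c(C(F)(F)F)c1` differs from compound 1 by a group of 9 heavy atoms (6 carbon, 3 nitrogen; one five-membered aromatic ring with 2 hetero atoms, one six-membered aromatic ring with 1 hetero atom) in place of a group of 10 heavy atoms (7 carbon, 2 nitrogen, 1 chlorine; one five-membered aromatic ring with 2 hetero atoms, one six-membered aromatic ring of carbon only), on an aromatic carbon. For the measured compounds named here, no measured step covers this kind of change, and the one step available was within the scatter, so for compound 3 the expectation is a step of a 1.3-fold higher number from compound 1 to compound 3 (0.11 log units; within the scatter). The estimate for compound 3 is therefore 4000 nM, with a range from 1500 nM to 12000 nM.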

Compound 3, half-maximal inhibitory concentration: 3400 nM
For compound 3 the middle estimate is 1.2-fold (0.07 log units) above the measured one; measured number inside the range.
By their numbers in this assay, from the lowest: compounds 1, 3 and 2 (each within the scatter of the next).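

Swapping the 4-chloro-1H-indazol-1-yl group for one whose six-membered aromatic ring holds a hetero atom and carries no chlorine gives a 1.1-fold higher number from compound 1 to compound 3 (0.04 log units; within the scatter) in this assay and so stays within the scatter. Thus a change to the ring itself at this place, and not only to the group on it, leaves the number where it was. Nothing shown gives a reason for this result. Going by these compounds, it remains open whether any group here can move the number beyond the scatter. An amine or a carboxylic acid on this ring would test that.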